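Swapping a methoxybenzyl for a hexyl chain on a shared core

The compounds below may be only part of what the source reports. "The series", "measured", "known", "first", "only" and "open" are said of these compounds alone.

Of the compounds shown here, two on a shared core have been measured. In a functional assay on the whole organism with Mus musculus as the target (on this read-out higher numbers stand for larger maximal responses and lower numbers for smaller maximal responses), compound 1 `C=CCn1c(=O)n([C@H]2CO[C@@H](CO)C2)c2nc(N)nc(O)c21` gives 16%. In this assay compound 2 `COc1ccc(Cn2c(=O)n(C3OC(CO)[C@@H](O)[C@H]3O)c3nc(N)nc(O)c32)cc1` gives 14%. Compound 2 holds the lower of the two figures, yet its gap to compound 1 lies within the usual scatter, so the two cannot be told apart on this read-out. Compound 3 `CCCCCCn1c(=O)n(C2OC(CO)[C@@H](O)[C@H]2O)c2nc(N)nc(O)c21` has not yet been measured. It differs from compound 2 in one place: pentyl in place of 4-methoxyphenyl on a saturated chain carbon bound to an aromatic nitrogen. Going by the values given here, no step between measured compounds is available to guide the size of this change, and both measured values sit close together at a low level. The step from compound 2 to compound 3 in this assay is therefore expected to be small, a number 1 percentage points higher from compound 2 to compound 3 (within the scatter), with no direction beyond the scatter. Compound 3 is estimated to reach 15% in this assay, within a range from 5% to 30%.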

Compound 3, largest response reached (reported as maximal response), in percent of the reference or control that the assay uses: 11%
The estimate for compound 3 lay 4 percentage points above the measured number; the measured number falls inside the stated range.
By their numbers in this assay, from the lowest: compounds 3, 2 and 1 (each within the scatter of the next).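

In this assay, going by these compounds alone, the exchange of 4-methoxybenzyl for hexyl gives a number 3 percentage points lower from compound 2 to compound 3 (within the scatter), the first step between measured compounds that differ in one place. At this position, on a saturated chain carbon bound to an aromatic nitrogen, the loss of the six-membered aromatic ring and its hydrogen-bond acceptor therefore produces no change that this read-out can separate from the scatter. No available evidence bears on this result.

From the compounds shown here alone, whether any group at this place can move the maximal response beyond the scatter remains open, since a single step within the scatter sets no trend. A decyl chain or a hexyl chain ending in an amine or a carboxylic acid would test this, as would an unsubstituted benzyl group.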